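From a Methoxybenzyl Amide to a Plain Anilide

The source may report more compounds than this note shows. Statements on the series, on what has been measured and on what is new or still open speak of the compounds shown alone.

Compound 1, `CC(C)(C)OC(=O)N1CCN(c2c(C(=O)NCc3ccc(F)cc3)nc(Br)c3cccnc23)CC1`, in a functional assay on HCT-116 cells (Homo sapiens) for cytotoxicity, read by MTT assay, with a stated time of 72 h (a lower number here means a stronger inhibitor, a higher number a weaker inhibitor), gives only a limit, > 10000 nM.
Compound 2, `COc1ccc(CNC(=O)c2nc(Br)c3cccnc3c2N[C@H]2CC[C@H](N)CC2)cc1`, in this assay gives 3000 nM.
Compound 3, `O=CNCCCCCCNc1nc(C(=O)NCc2ccc(F)cc2)c(O)c2ncccc12`, in this assay gives 4000 nM.

Of the two numbers that were actually obtained, compound 2 shows the lower one, yet its distance from compound 3 lies within the usual scatter of repeated measurements, so the two cannot be ranked against each other. For compound 1 the measurement stops at the limit of > 10000 nM in this assay, at which 1 of the 3 values shown sits.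

Compound 4, `N[C@H]1CC[C@H](Nc2c(C(=O)Nc3ccccc3)nc(Br)c3cccnc23)CC1`, has not yet been measured. It differs from compound 2 in one place: phenyl in place of 4-methoxybenzyl on an amide-type nitrogen. For the measured compounds named here, no step between two measured compounds is available here, so no measured change offers a foothold for the size of this one. The expectation is a small move toward a higher number, close to the edge of the scatter, and the estimated step is a 1.7-fold higher number from compound 2 to compound 4 (0.22 log units; within the scatter). Compound 4 is thus expected to give 5000 nM, with the estimate spanning from 1500 nM to 20000 nM.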

Compound 4, half-maximal inhibitory concentration: 2000 nM
The estimate for compound 4 lay 2.5-fold (0.40 log units) above the measured number; the measured number falls inside the stated range.
By their numbers in this assay, from the lowest: compounds 4, 2 and 3 (each within the scatter of the next). At a limit, above all of these: compound 1.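

The first step measured at this amide-type nitrogen, in this assay, is a 1.5-fold lower number from compound 2 to compound 4 (0.18 log units; within the scatter). Replacing 4-methoxybenzyl with phenyl gives a group with fewer heavy atoms and no hydrogen-bond acceptor, yet compound 4 cannot be told apart from compound 2 in this read-out, so this particular change shows no measurable effect on cytotoxicity. Nothing measured among these compounds offers an explanation for this result.

From the compounds shown here alone, it remains open whether a larger change at this nitrogen, such as a longer chain like 2-phenylethyl, or an amine or a carboxylic acid carried on the phenyl ring, would move the number beyond the scatter. Going by these compounds, it also remains open whether the same change would behave alike in compounds that carry other groups on the shared core.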